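A few compounds are considered here, and "the series" means these few. Any claim that something is new, unique, unknown or untested is made for them only; others in the source may bear on it.

Three sulfonamides have been measured in an ADME assay. Compound 1, with the structure `O=S(=O)(Nc1ccccc1)c1ccccc1`, gives 9.1 and stands highest of the three numbers. Compound 2, `O=S(=O)(Nc1ccccc1)c1ccc(Cl)cc1`, gives 8.47, and compound 3, `O=[N+]([O-])c1cccc(S(=O)(=O)Nc2ccccc2)c1`, gives 7.5. Both steps away from compound 1 went downward: a number 0.63 log units lower from compound 1 to compound 2 (beyond the scatter), and a number 1.60 log units lower from compound 1 to compound 3 (beyond the scatter).

The next compound, compound 4, has the structure `O=S(=O)(Nc1ccc(Cl)cc1)c1ccccc1`. Compared with compound 1 the change is chloro in place of hydrogen on an aromatic carbon. For the measured compounds named here, the step that bears most directly on it is the one to compound 2, since it adds the same chloro group, though in compound 2 that group sits on the other six-membered ring of the shared core; that step was a number 0.63 log units lower from compound 1 to compound 2 (beyond the scatter), a modest fall. The step to compound 3, a number 1.60 log units lower from compound 1 to compound 3 (beyond the scatter), involved a different group and is a less direct guide. Going by the values given here, a downward step beyond the scatter, somewhat smaller than the one to compound 2, is therefore expected, namely a number 0.50 log units lower from compound 1 to compound 4 (beyond the scatter). Compound 4 is thus estimated at 8.6 in this assay, within a range from 8.3 to 8.9.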

Compound 4, acid dissociation constant: 8.75
For compound 4 the middle estimate is 0.15 log units below the measured one, and the stated range covers the measured number.
By their numbers in this assay, from the lowest: compound 3; then compounds 2 and 4 (each within the scatter of the next); then compound 1.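

Chloro on this second six-membered ring of the shared core, para to a large group, also lowers the number in this assay, giving a number 0.35 log units lower from compound 1 to compound 4 (beyond the scatter). So the fall seen with chloro is not confined to the ring that carries it in compound 2: compound 2 at 8.47 and compound 4 at 8.75 lie within the scatter of each other, and the two placements cannot be told apart in this assay. No measurement shown here accounts for the fall at this position.

Still open, as far as these compounds go, is whether an amine or a methoxy group at this position would lower the number as chloro does, or raise it instead. From the compounds shown here alone, it is also open how large a step nitro would give on this ring, as compound 3 carries that group only on the other ring.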